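Trimming the Trifluoromethyl: From Compound 3 to Compound 4

A few compounds are considered here, and "the series" means these few. Any claim that something is new, unique, unknown or untested is made for them only; others in the source may bear on it.

Of the compounds shown here, three have been measured in a functional assay on A498 cells (Homo sapiens) for inhibition, read by sulforhodamine B assay, with a stated time of 48 h (on this read-out lower numbers stand for stronger inhibition of growth and higher numbers for weaker inhibition of growth), all sharing one core. Compound 1 `O=C(Nc1cccc(-n2cc(-c3ccncc3)c(-c3ccc(Cl)c(O)c3)n2)c1)Nc1ccc(Cl)c(Cl)c1` gives 3170 nM, compound 2 `COc1cc(-c2nn(-c3cccc(NC(=O)c4cccc(C(F)(F)F)c4)c3)cc2-c2ccncc2)ccc1Cl` gives 2780 nM, and compound 3 `COc1cc(-c2nn(-c3cccc(NC(=O)Nc4cccc(C(F)(F)F)c4)c3)cc2-c2ccncc2)ccc1Cl` gives 4040 nM, the highest of the three numbers, though every gap between them lies within the scatter of this assay. Compound 4 `COc1cc(-c2nn(-c3cccc(NC(=O)c4ccccc4)c3)cc2-c2ccncc2)ccc1Cl` differs from compound 3 in one place: phenyl in place of (3-(trifluoromethyl)phenyl)amino on a carbonyl carbon. Going by the values given here, the only measured step that bears on this, a 1.5-fold higher number from compound 2 to compound 3 (0.16 log units; within the scatter), swapped the same two kinds of linkage and stayed within the scatter. Among the compounds with values here, no measured pair shows what losing the trifluoromethyl does, so the estimated step of a 1.2-fold lower number from compound 3 to compound 4 (0.06 log units; within the scatter) is small. Compound 4 is expected to give about 3500 nM, between 1500 nM and 8000 nM.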

Compound 4, concentration for total growth inhibition: 3140 nM
The estimate for compound 4 lay 1.1-fold (0.05 log units) above the measured number, and the stated range covers the measured number.
By their numbers in this assay, from the lowest: compounds 2, 4, 1 and 3 (each within the scatter of the next).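

Going by these compounds alone, compound 2 and compound 4 give the first direct look at losing the trifluoromethyl from the aromatic ring, and in this assay that change stays within the scatter (a 1.1-fold higher number from compound 2 to compound 4 (0.05 log units; within the scatter)). Replacing the whole (3-(trifluoromethyl)phenyl)amino with phenyl on the carbonyl carbon also stays within the scatter (a 1.3-fold lower number from compound 3 to compound 4 (0.11 log units; within the scatter)). No supporting measurement is available to explain either result. Still open, as far as these compounds go, is whether an amine or a carboxylic acid on that aromatic ring would move the number beyond the scatter.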